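From benzyloxycarbonyl to methoxycarbonyl: an expected stability shift

The source may hold more compounds than are shown below. What is called first, only, known or untested is meant among the compounds shown, and "the series" means these compounds.

Going by the values given here, only two compounds have been measured in an ADME assay on S9 fraction from liver (Rattus norvegicus), read by LC-MS, with a stated time of 60 min, at 37 degrees C (on this read-out higher numbers stand for a more stable compound and lower numbers for a less stable compound), and compound 2 `C[C@@H]1CN(C(=O)c2nc(Nc3cc(C4CC4)[nH]n3)c3cc(Cl)ccc3n2)CCN1C(=O)OCc1ccccc1` holds the higher number, with 45.6% left, while compound 1 `CC(C)C(=O)OCOC(=O)N1CCN(C(=O)c2nc(Nc3cc(C4CC4)[nH]n3)c3cc(Cl)ccc3n2)C[C@H]1C` gives 14%. Compound 3 `COC(=O)N1CCN(C(=O)c2nc(Nc3cc(C4CC4)[nH]n3)c3cc(Cl)ccc3n2)C[C@H]1C` has not yet been measured. It shares its core with compound 2 and differs in one group: hydrogen in place of phenyl on a saturated chain carbon bound to an oxygen next to a carbonyl group. In words, this is hydrogen in place of phenyl on a saturated chain carbon bound to an oxygen next to a carbonyl group, so benzyloxycarbonyl becomes methoxycarbonyl.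

Among the compounds with values here, only one measured step bears on this change. It is a number 31.6 percentage points higher from compound 1 to compound 2 (beyond the scatter), a large step beyond the scatter, made by placing phenyl instead of (isopropylcarbonyl)oxy on that same carbon. Within the data shown here, it shows that the read-out can respond strongly to what sits there, but no measured compound carries hydrogen at this place, so any forecast is uncertain. The expected result is a number 14.4 percentage points higher from compound 2 to compound 3 (beyond the scatter), a rise that is smaller than the measured step. For compound 3 the estimated value is 60%, with an expected range from 35% to 85%.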

Compound 3, percent of the compound remaining: 34.2%
Compound 3: middle estimate off by 25.8 percentage points, on the high side; the whole stated range lies above it.
By their numbers in this assay, from the lowest: compound 1; then compound 3; then compound 2.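

In this assay, swapping phenyl for hydrogen on this saturated chain carbon gives a number 11.4 percentage points lower from compound 2 to compound 3 (beyond the scatter) and so shows that the smallest possible group does not give the highest number here. Placing hydrogen instead of (isopropylcarbonyl)oxy on the same carbon gives a number 20.2 percentage points higher from compound 1 to compound 3 (beyond the scatter) and places hydrogen between the two larger groups, so the earlier gap between them can now be split into two measured parts, with phenyl highest and (isopropylcarbonyl)oxy lowest among these three compounds. Nothing available explains why the three groups fall in this order.

Going by these compounds alone, with only three groups compared at this carbon, it remains open whether the order follows any simple trend or reflects something particular to each group. An ethyl group or a longer chain, an amine or a carboxylic acid on this carbon could help settle that, and it is also unknown whether the same order would hold on a core other than the one shared here.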